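From 2,4-dichlorophenyl to 4-cyanophenyl in growth inhibition

This account rests on a few compounds, and the source may have more. Where it says the series, first, only, none or still open, it means among the compounds named here.

In a functional assay on DU-145 cells (Homo sapiens) for inhibition, read by trypan blue exclusion, with a stated time of 96 h (a lower number here means a stronger inhibitor of growth, a higher number a weaker inhibitor of growth), compound 1 (`O=C(/C(=C\c1ccc(Cl)cc1)S(=O)(=O)c1ccc(Br)cc1)c1ccc(Br)cc1`) gives 50000 nM. Compound 2 (`O=C(/C(=C\c1ccc(O)c([N+](=O)[O-])c1)SCc1ccc(Br)cc1)c1ccc(Cl)cc1Cl`) gives 10000 nM, the lower of the two numbers and beyond the scatter of compound 1, which makes it the stronger growth inhibitor of the pair. Compound 3 (`N#Cc1ccc(C(=O)/C(=C\c2ccc(O)c([N+](=O)[O-])c2)SCc2ccc(Br)cc2)cc1`) differs from compound 2 in one place, with 4-cyanophenyl in place of 2,4-dichlorophenyl on a carbonyl carbon. Going by the values given here, no measured pair of compounds differs in one place, so the data give no direct guide to the effect of this change. The expectation therefore starts from compound 2 at 10000 nM, and no shift beyond the scatter is expected in either direction. The expected size is no change at the digits printed from compound 2 to compound 3 (within the scatter). The estimate for compound 3 is 10000 nM, with an expected range from 3000 nM to 40000 nM.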

Compound 3, concentration for 50% growth inhibition: 10000 nM
Beside the measured number, compound 3's estimate shows no gap at the digits printed; the range from low to high includes it.
By their numbers in this assay, from the lowest: compounds 2 and 3 (each within the scatter of the next); then compound 1.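

The step gives the first comparison among these compounds that differs in only one place: in this assay, replacing 2,4-dichlorophenyl with 4-cyanophenyl on a carbonyl carbon gives no change at the digits printed from compound 2 to compound 3 (within the scatter). At this position, then, a nitrile-bearing phenyl group can take the place of the dichlorinated one, with the same count of heavy atoms in the group, and growth inhibition shows no difference beyond the scatter. Nothing measured on these compounds bears on why the two groups read alike.

Going by these compounds, it remains open whether a carboxylic acid or an amine in place of the nitrile would read the same at this position. Also open, on these data alone, is whether the same exchange would read alike on the core of compound 1, which differs from compound 2 in more than one place.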